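Bromo to trifluoromethyl on the anilide: compound 4

The compounds below may be only part of what the source reports. "The series", "measured", "known", "first", "only" and "open" are said of these compounds alone.

Measured in a functional assay on T47D cells (Homo sapiens) for inhibition, read by CCK-8 assay, with a stated time of 72 h, tested at 10 uM; on this read-out higher numbers stand for more inhibition of growth at the one concentration tested and lower numbers for less inhibition of growth:
compound 1 `CN(C)C(=O)c1cc2cnc(Nc3ccc(NC(=O)C4(C(=O)Nc5cccc(O)c5)CC4)cc3)nc2n1C1CCCC1`: 83.7%
compound 2 `CN(C)C(=O)c1cc2cnc(Nc3ccc(NC(=O)C4(C(=O)Nc5ccccc5F)CC4)cc3)nc2n1C1CCCC1`: 97.8%
compound 3 `CN(C)C(=O)c1cc2cnc(Nc3ccc(NC(=O)C4(C(=O)Nc5ccc(Br)cc5)CC4)cc3)nc2n1C1CCCC1`: 94.3%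

The starting point is compound 3 at 94.3%. It sits with the upper pair of the set: the gap there is a number 3.5 percentage points lower from compound 2 to compound 3 (within the scatter), whereas the clear gap is a number 10.6 percentage points higher from compound 1 to compound 3 (beyond the scatter).

The next compound, compound 4 `CN(C)C(=O)c1cc2cnc(Nc3ccc(NC(=O)C4(C(=O)Nc5ccc(C(F)(F)F)cc5)CC4)cc3)nc2n1C1CCCC1`, carries trifluoromethyl in place of bromo on an aromatic carbon, para to a large group (trifluoromethyl in place of bromo on an aromatic carbon). Among the compounds with values here, no measured step makes this exact exchange. The closest evidence is the swap between two aryl groups without a hydroxyl, which stayed small at a number 3.5 percentage points lower from compound 2 to compound 3 (within the scatter). Within the data shown here, the only steps beyond the scatter, a number 14.1 percentage points higher from compound 1 to compound 2 (beyond the scatter) and a number 10.6 percentage points higher from compound 1 to compound 3 (beyond the scatter), both start from the 3-hydroxyphenyl compound and are modest, so they bear on this change only weakly. The expected result is a number 2.3 percentage points lower from compound 3 to compound 4 (within the scatter), which would be no shift beyond the scatter.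

Compound 4 is estimated at 92%, with an expected range of 81% to 100%.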

Compound 4, percent growth inhibition at one concentration: 94.9%
Compound 4: the middle estimate sits 2.9 percentage points below what was measured, and the stated range covers the measured number.
By their numbers in this assay, from the lowest: compound 1; then compounds 3, 4 and 2 (each within the scatter of the next).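

In this assay, trifluoromethyl in place of bromo on an aromatic carbon, para to a large group, gives a number 0.6 percentage points higher from compound 3 to compound 4 (within the scatter) and so brings 4 heavy atoms where 1 stood without a shift beyond the scatter. Against the 2-fluorophenyl anilide the result is also flat, with a number 2.9 percentage points lower from compound 2 to compound 4 (within the scatter) and the hydroxyl-bearing anilide stays apart, with a number 11.2 percentage points higher from compound 1 to compound 4 (beyond the scatter) and thus compound 2, compound 3 and compound 4 form one group with three different halogen-bearing aryl groups. No measured property of these compounds offers a reason for this result.

From the compounds shown here alone, with a single concentration, what separates compound 2, compound 3 and compound 4 stays open. Going by these compounds, how an amine or a carboxylic acid in place of trifluoromethyl on this ring would read also remains open.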